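A few compounds are considered here, and "the series" means these few. Any claim that something is new, unique, unknown or untested is made for them only; others in the source may bear on it.

Working notes on a series sharing one cationic core with an alkoxime, tested in a functional assay on ACHN cells (Homo sapiens) for cytotoxicity; a higher number here means a weaker inhibitor, a lower number a stronger inhibitor. Compound 1 `CO/N=c1\[nH]cnc2c1[n+](Cc1ccccc1)cn2C` gives only a limit of the assay, > 80000 nM. For compound 1 this is the limit of > 80000 nM in this assay, at which 1 of the 3 values shown sits. Compound 2 `CC(C)=CCC/C(C)=C/CC/C(C)=C/CC/C(C)=C/C[n+]1cn(C)c2nc[nH]/c(=N\OC(C)(C)C)c21` gives 8400 nM. Compound 3 `CO/N=c1\[nH]cnc2c1[n+](C/C=C(\C)CC/C=C(\C)CC/C=C(\C)CCC=C(C)C)cn2C(C)C` gives 2450 nM, the lower of the two numbers recorded; compound 2 sits at the next higher number, and that gap is beyond the scatter. Compound 4 `CO/N=c1\[nH]cnc2c1[n+](C/C=C(\C)CC/C=C(\C)CC/C=C(\C)CCC=C(C)C)cn2Cc1ccccc1` carries benzyl in place of isopropyl on an aromatic nitrogen. Within the data shown here, no measured pair of compounds shows this change alone. The expected step from compound 3 to compound 4 is small, a 1.4-fold lower number from compound 3 to compound 4 (0.13 log units; within the scatter), and is not expected to reach clearly beyond the scatter. Compound 4 is estimated at 1800 nM, with a range from 600 nM to 6000 nM.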

Compound 4, half-maximal inhibitory concentration: 3400 nM
Beside the measured number, compound 4's estimate is 1.9-fold (0.28 log units) below it; measured number inside the range.
By their numbers in this assay, from the lowest: compounds 3 and 4 (each within the scatter of the next); then compound 2. At a limit, above all of these: compound 1.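

On the aromatic nitrogen of the five-membered ring, benzyl in place of isopropyl is the only single-place change shown, and in this assay it reads as a 1.4-fold higher number from compound 3 to compound 4 (0.14 log units; within the scatter). This position therefore accepts a six-membered aromatic ring of carbon only without a change beyond the scatter. Nothing measured here gives a cause for this step.

Going by these compounds, it remains open how a group carrying an amine or a carboxylic acid would read at this nitrogen. Compound 1 and compound 2 differ from compound 3 in more than one place, so the separate contributions of the long chain and the alkoxime cannot be read.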